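Amide-to-ester exchange on a 2-aminothiophene-free shared core

The source may report more compounds than this note shows. Statements on the series, on what has been measured and on what is new or still open speak of the compounds shown alone.

Of the compounds shown here, two have been measured in a functional assay on PC-3 cells (Homo sapiens) for inhibition, read by sulforhodamine B assay, with a stated time of 72 h; a lower number here means a stronger inhibitor, a higher number a weaker inhibitor. Compound 1 `Nc1sc(-c2ccc(Cl)cc2)c(-c2ccc(Cl)cc2)c1C(=O)NC1CCCCC1` gives 7300 nM in this assay. For the measured compounds named here, compound 2 `COc1ccc(CNC(=O)c2c(N)sc(-c3ccc(Cl)cc3)c2-c2ccc(Cl)cc2)cc1` gives 29500 nM, which stands highest of the two numbers; the only measured step is a 4.0-fold higher number from compound 1 to compound 2 (0.61 log units; beyond the scatter). Compound 3 `COC(=O)c1c(N)sc(-c2ccc(Cl)cc2)c1-c1ccc(Cl)cc1` differs from compound 2 by methoxy in place of (4-methoxybenzyl)amino on a carbonyl carbon. Going by the values given here, no measured step touches the carbonyl carbon itself; the step from compound 1 to compound 2 only shows that exchanging the group on the amide nitrogen moved the number by a modest amount. With nothing closer to lean on, compound 3 is expected to land somewhere between the two measured numbers, and the estimated step of a 2.0-fold lower number from compound 2 to compound 3 (0.29 log units; within the scatter) is a modest lowering whose direction is not secure. Compound 3 is therefore estimated at 15000 nM in this assay, with a range from 4000 nM to 60000 nM.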

Compound 3, half-maximal inhibitory concentration: 2780 nM
The estimate for compound 3 lay 5.4-fold (0.73 log units) above the measured number; measured number outside the range, below it.
By their numbers in this assay, from the lowest: compound 3; then compound 1; then compound 2.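

In this assay, the carbonyl carbon proves to be a place where the number can fall as well as rise: an 11-fold lower number from compound 2 to compound 3 (1.03 log units; beyond the scatter) follows when methoxy replaces (4-methoxybenzyl)amino, and a 2.6-fold lower number from compound 1 to compound 3 (0.42 log units; beyond the scatter) follows when methoxy replaces cyclohexylamino. Compound 3 thus has the lowest number of the three, and both steps lie beyond the scatter, so among these compounds neither an amide nitrogen nor its hydrogen is needed for the lowest value. Nothing available here bears on why this exchange lowers the number.

The compounds shown leave open how a carboxylic acid, a primary amide or a longer chain such as ethoxy on the carbonyl carbon would compare with methoxy. They also leave open whether the lowering would persist with groups other than 4-chlorophenyl on the shared core.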